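Aryl piperazine amides of a succinimide: aryl substituent survey

The source may hold more compounds than are shown below. What is called first, only, known or untested is meant among the compounds shown, and "the series" means these compounds.

Measured compounds in a functional assay on the whole organism (strain Swiss) with Mus musculus as the target, in the maximal electroshock model, with a stated time of 0.25 h, at a dose of 300 mg/kg by the intraperitoneal route; a higher number here means a stronger effect of the compound at the dose given, a lower number a weaker effect:
- compound 1 `COc1cccc(N2CCN(C(=O)C(C)N3C(=O)CCC3=O)CC2)c1` gives 75%
- compound 2 `CC(C(=O)N1CCN(c2ccc(Cl)cc2)CC1)N1C(=O)CCC1=O` gives 100%
- compound 3 `CC(C(=O)N1CCN(c2ccccc2F)CC1)N1C(=O)CCC1=O` gives 100%

Compound 1 stands lowest of the three in this assay. Both measured steps away from it are increases: a number 25 percentage points higher from compound 1 to compound 2 (beyond the scatter) and a number 25 percentage points higher from compound 1 to compound 3 (beyond the scatter); between the two higher compounds, no change at the digits printed from compound 2 to compound 3 (within the scatter).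

Compound 4 `CC(C(=O)N1CCN(c2cccc(C(F)(F)F)c2)CC1)N1C(=O)CCC1=O` differs from compound 1 by a single change: trifluoromethyl in place of methoxy on an aromatic carbon. Going by the values given here, no measured step exchanges one group on the aryl ring alone; the two known steps replace the whole aryl group and both raise the read-out by the same modest amount. The change to compound 4 is of a different kind, so those steps bear on it only loosely. An increase toward the upper end of the scale is expected, with the size of a number 15 percentage points higher from compound 1 to compound 4 (beyond the scatter) taken from the two known steps. Compound 4 is therefore estimated at 90%, between 70% and 100%.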

Compound 4, a percentage reported as activity, at one dose (the size of the read-out at that dose, not a potency): 75%
Estimate against measurement, compound 4: 15 percentage points above; the range from low to high includes it.
By their numbers in this assay, from the lowest: compounds 1 and 4 (each within the scatter of the next); then compounds 2 and 3 (each within the scatter of the next).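

In this assay, trifluoromethyl in place of methoxy on an aromatic carbon, meta to a large group, gives no change at the digits printed from compound 1 to compound 4 (within the scatter). Going by these compounds alone, this is the first step that exchanges one group on the aryl ring alone, and it does not bring the rise seen when the whole aryl group is replaced. No available evidence explains this result.

Going by these compounds, whether an amine or a carboxylic acid on this same aromatic carbon would move the read-out remains open. The shown compounds also leave open whether methoxy and trifluoromethyl would stay level on a different carbon of the ring.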